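Lengthening a Side Chain Toward Compound 4

The source may report more compounds than this note shows. Statements on the series, on what has been measured and on what is new or still open speak of the compounds shown alone.

Compound 1, `CCC(CCO)n1cnc2c(Cl)ncnc21`, in a functional assay on HCT-116 cells (Homo sapiens) for antiproliferative activity, read by MTT assay, with a stated time of 48 h (a lower number here means a stronger inhibitor, a higher number a weaker inhibitor), gives > 50000 nM, which is a limit of the assay and not a number.
Compound 2, `CCCC(CCO)n1cnc2c(Cl)ncnc21`, in this assay gives > 50000 nM, again a limit and not a number.
Compound 3, `CCCCCC(CCO)n1cnc2c(Cl)nc(F)nc21`, in this assay gives 8660 nM.

The step from compound 1 to compound 2 is methyl in place of hydrogen on a saturated chain carbon, three bonds along the chain from an aromatic nitrogen. Its size, a step that the two limits leave unreadable from compound 1 to compound 2, cannot be read because of the limit of > 50000 nM in this assay, at which 2 of the 3 values shown sit. For the measured compounds named here, that leaves compound 3 as the only compound with a number to build on.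

Compound 4, `CCCCCCC(CCO)n1cnc2c(Cl)nc(F)nc21`, has not yet been measured. It differs from compound 3 by methyl in place of hydrogen on a saturated chain carbon, six bonds along the chain from an aromatic nitrogen. Going by the values given here, this is the same kind of change as the one from compound 1 to compound 2, but not the same: there the new methyl sits three bonds along the chain from an aromatic nitrogen, here six bonds along the chain from an aromatic nitrogen. The difference between the core of compound 1 and the core of compound 3 is not broken down here.

Beside the unreadable earlier step, the step expected from compound 3 to compound 4 is a 1.2-fold lower number from compound 3 to compound 4 (0.09 log units; within the scatter), a small one, since the change adds only a methyl and nothing else shown speaks for a large shift. Compound 4 is therefore estimated at 7000 nM in this assay, expected to fall between 2500 nM and 25000 nM.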

Compound 4, half-maximal inhibitory concentration: 9960 nM
Beside the measured number, compound 4's estimate is 1.4-fold (0.15 log units) below it; the range from low to high includes it.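

In this assay, the added methyl on the longer chain gives a 1.2-fold higher number from compound 3 to compound 4 (0.06 log units; within the scatter), so this pair cannot be told apart and, on this core, the change brings no measurable gain in strength of inhibition. The same kind of change on the core of compound 1, where the new methyl sits three bonds along the chain from an aromatic nitrogen rather than six, cannot be read, because both compounds of that pair stop at a limit of the assay: the limit of > 50000 nM in this assay, at which 2 of the 4 values shown sit. That leaves a single readable step on a single core, and the two cases also differ in where the methyl sits, so these compounds show neither that the change carries over from one core to the other nor that it fails to.

The compounds shown leave open how a longer chain would read in this assay on the core of compound 3, and whether the flat result seen with this one added methyl would hold further out. They also leave open what an amine or a carboxylic acid in this side chain would do, and whether any compound on the core of compound 1 would give a number rather than a limit.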